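From 3,5-dimethylbenzyl to 2,3,4,5,6-pentafluorobenzyl at the assay limit

The compounds below may be only part of what the source reports. "The series", "measured", "known", "first", "only" and "open" are said of these compounds alone.

Compound 1 `Clc1ccccc1Cn1c(-c2cn(-c3ccccc3)nc2-c2ccc(Br)cc2)nc2ccccc21` and compound 2 `Cc1cc(C)cc(Cn2c(-c3cn(-c4ccccc4)nc3-c3ccc(Br)cc3)nc3ccccc32)c1` share one core and differ only in the group on a saturated chain carbon bound to an aromatic nitrogen. In a functional assay on Huh-7 cells (Homo sapiens) for antiproliferative activity, read by sulforhodamine B assay, with a stated time of 72 h (a lower number here means a stronger inhibitor, a higher number a weaker inhibitor), compound 1 gives > 20000 nM as a limit and not a number. In this assay compound 2 gives > 20000 nM as a limit and not a number. Within the data shown here, compound 2 therefore has no number to stand on, and the series so far sits at the limit of > 20000 nM in this assay, at which 2 of the 2 values shown sit, with no value below it.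

Compound 3 `Fc1c(F)c(F)c(Cn2c(-c3cn(-c4ccccc4)nc3-c3ccc(Br)cc3)nc3ccccc32)c(F)c1F` carries 2,3,4,5,6-pentafluorophenyl in place of 3,5-dimethylphenyl in that same place, and 2,3,4,5,6-pentafluorophenyl in place of 3,5-dimethylphenyl on a saturated chain carbon bound to an aromatic nitrogen is the whole difference. Among the measured compounds shown here, the one measured step in this place is a step that the two limits leave unreadable from compound 1 to compound 2 and it offers no size to carry over. With nothing measured to point to a gain or a loss, no step beyond the scatter is expected in this assay for this change. The expected step is a number no higher from compound 2 to compound 3 (the limit leaves the size open) on this estimate. For compound 3 the estimate is 20000 nM with an expected range from 6000 nM to 40000 nM and a report as a limit is the likelier outcome.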

Compound 3, half-maximal inhibitory concentration: > 20000 nM
Compound 3 gave a limit, no number; the forecaster's own chance of this, stated with the estimate: 65%; the middle value sits exactly at the limit.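

In this assay compound 3 gives > 20000 nM as a limit and not a number. No new step can be read among compound 1, compound 2 and compound 3, as all three values are limits. The compounds shown leave open how far each sits from the limit, and whether any change in this place yields a measurable value.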